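This account rests on a few compounds, and the source may have more. Where it says the series, first, only, none or still open, it means among the compounds named here.

Measured so far:
compound 1 `c1ccc(-c2cc(-c3cccnc3)nc(-c3ccccn3)c2)cc1` — 0.33 ug/mL
compound 2 `c1ccc(-c2cc(-c3ccsc3)cc(-c3ccccn3)n2)nc1` — 0.0027 ug/mL
compound 3 `c1ccc(-c2cc(-c3ccccn3)nc(-c3ccccn3)c2)cc1` — 0.0014 ug/mL

In a functional assay on HT-29 cells (Homo sapiens) for antiproliferative activity (on this read-out higher numbers stand for weaker inhibition of growth and lower numbers for stronger inhibition of growth), compound 3 gives 0.0014 ug/mL, the lowest of the three numbers. Compound 2 stands nearest: a 1.9-fold lower number from compound 2 to compound 3 (0.29 log units; within the scatter). Compound 1 stands furthest: a 240-fold lower number from compound 1 to compound 3 (2.37 log units; beyond the scatter).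

Compound 4 `c1ccc(-c2cc(-c3ccco3)cc(-c3ccccn3)n2)nc1` differs from compound 3 in one place: furan-2-yl in place of phenyl on an aromatic carbon. For the measured compounds named here, only one measured step bears on this change, a 1.9-fold lower number from compound 2 to compound 3 (0.29 log units; within the scatter), where a five-membered ring with one hetero atom also stood in place of phenyl on an aromatic carbon, and it stayed within the scatter. The other step, a 240-fold lower number from compound 1 to compound 3 (2.37 log units; beyond the scatter), concerns a different ring. For this assay the expected step is therefore small, a 1.4-fold higher number from compound 3 to compound 4 (0.15 log units; within the scatter), with no direction beyond the scatter. Compound 4 is expected to give 0.002 ug/mL, within 0.0007 ug/mL to 0.006 ug/mL.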

Compound 4, concentration for 50% growth inhibition: 0.0024 ug/mL
Compound 4: the middle estimate sits 1.2-fold (0.08 log units) below what was measured; the measured number falls inside the stated range.
By their numbers in this assay, from the lowest: compounds 3, 4 and 2 (each within the scatter of the next); then compound 1.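

At the position opposite the ring nitrogen, furan-2-yl now joins phenyl and thiophen-3-yl as a ring that keeps the number very low. In this assay the change from phenyl gives a 1.7-fold higher number from compound 3 to compound 4 (0.23 log units; within the scatter) and the change between the two five-membered rings gives a 1.1-fold lower number from compound 2 to compound 4 (0.05 log units; within the scatter), so an oxygen-containing five-membered ring fits the same narrow range as the other two. No measurement here explains this result. As far as these compounds go, whether an amine or a carboxylic acid at this position would keep the number this low remains open.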